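From Octyl to 3-(4-Methylphenoxy)propyl on the Shared Core

The source may hold more compounds than are shown below. What is called first, only, known or untested is meant among the compounds shown, and "the series" means these compounds.

In a functional assay on HCT-116 cells (Homo sapiens) for antiproliferative activity, read by MTT assay, with a stated time of 48 h (a higher number here means a weaker inhibitor of growth, a lower number a stronger inhibitor of growth), compound 1 `Cc1ccc(-c2cnc(N(Cc3ccccc3)Cc3ccc(C(=O)NO)cc3)s2)cc1` gives 48800 nM, while compound 2 `CCCCCCCCN(Cc1ccc(C(=O)NO)cc1)c1ncc(-c2ccc(C)cc2)s1` gives 6500 nM, the lower of the two numbers. Compound 2 therefore stands as the stronger inhibitor of growth in this small set, though its value remains in the micromolar range. Compound 3 `Cc1ccc(OCCCN(Cc2ccc(C(=O)NO)cc2)c2ncc(-c3ccc(C)cc3)s2)cc1` keeps the core of compound 2 and differs only at the outer part of the chain on the nitrogen: 4-methylphenoxy in place of pentyl on a saturated chain carbon, three bonds along the chain from a nitrogen on an aromatic ring. Read one bond further out, octyl gives way to 3-(4-methylphenoxy)propyl.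

Among the compounds with values here, only one measured step bears on this change, and only indirectly. Exchanging phenyl for heptyl gave a 7.5-fold lower number from compound 1 to compound 2 (0.88 log units; beyond the scatter), showing that the group at this nitrogen can move the number. No measured compound carries 4-methylphenoxy, so the direction of the new change is not shown by the data. The chain start is retained, and no step beyond the scatter is expected on that limited basis. The expected change is a 1.2-fold lower number from compound 2 to compound 3 (0.07 log units; within the scatter). Compound 3 is estimated at 5500 nM, with an expected range from 1800 nM to 17000 nM.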

Compound 3, concentration for 50% growth inhibition: 12600 nM
The estimate for compound 3 lay 2.3-fold (0.36 log units) below the measured number; the measured number falls inside the stated range.
By their numbers in this assay, from the lowest: compounds 2 and 3 (each within the scatter of the next); then compound 1.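

In this assay, putting 4-methylphenoxy in place of pentyl gives a 1.9-fold higher number from compound 2 to compound 3 (0.29 log units; within the scatter) on the saturated chain carbon, three bonds along the chain from a nitrogen on an aromatic ring, so this position carries a six-membered aromatic ring and an ether oxygen with no step beyond the scatter. The comparison with the phenyl group gives a 3.9-fold lower number from compound 1 to compound 3 (0.59 log units; beyond the scatter) when 2-(4-methylphenoxy)ethyl takes its place, which shows that a six-membered aromatic ring in this group does not by itself tie the number to that of compound 1. No accompanying evidence bears on the reason for either step.

The ring, its methyl group and the ether oxygen enter together in compound 3, so their separate contributions cannot be read from these compounds. Also open, going by these compounds, is how the number would respond to an amine or a carboxylic acid at the outer end of the chain, to a plain phenoxy group, or to a chain longer than octyl.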